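Moving the ring methyl on the benzyl thioether

The source may hold more compounds than are shown below. What is called first, only, known or untested is meant among the compounds shown, and "the series" means these compounds.

The shared core is that of compound 1 `O=c1c2ccccc2[se]n1-c1nc(SCc2ccccc2)n[nH]1`, which in an ADME assay on L929 cells (Mus musculus) for antiproliferative activity, read by CCK-8 assay, with a stated time of 48 h (a lower number here means a stronger inhibitor, a higher number a weaker inhibitor), gives > 50000 nM, a limit of the assay. Compound 2 `CCSc1n[nH]c(-n2[se]c3ccccc3c2=O)n1` gives 35200 nM in this assay. Compound 3 `Cc1ccc(CSc2n[nH]c(-n3[se]c4ccccc4c3=O)n2)cc1` gives > 50000 nM, again a limit. Compound 3 therefore stands at the limit of > 50000 nM in this assay, at which 2 of the 3 values shown sit, so its position within the series is known only as a limit. The measured steps near it are an at least 1.4-fold higher number from compound 2 to compound 3 (0.15 log units; that floor lies within the scatter) and a step that the two limits leave unreadable from compound 1 to compound 3. Compound 4 `Cc1cccc(CSc2n[nH]c(-n3[se]c4ccccc4c3=O)n2)c1` differs from compound 3 by 3-methylphenyl in place of 4-methylphenyl on a saturated chain carbon bound to a sulfur. Within the data shown here, no measured step separates two placements of the methyl on that ring, and the one step touching a methylphenyl reached only the limit. Compound 4 is thus expected to stay near the limit, a step that the limit leaves unreadable from compound 3 to compound 4, with no step beyond the scatter. The estimate for compound 4 is 60000 nM, ranging from 30000 nM to 120000 nM.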

Compound 4, half-maximal inhibitory concentration: > 50000 nM
Compound 4: no number, only a limit; the forecaster's own chance of this, stated with the estimate: 75%; the middle value is on the limit's open side.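

In this assay, 3-methylphenyl in place of 4-methylphenyl gives no readable change, since compound 4 also sits at a limit and the steps among compound 1, compound 3 and compound 4 cannot be read. Among these compounds, the one readable step is an at least 1.4-fold higher number from compound 2 to compound 4 (0.15 log units; that floor lies within the scatter). Neither placement of the methyl moves the series off the ceiling: the limit of > 50000 nM in this assay, at which 3 of the 4 values shown sit.

Any difference between the two placements beyond the limit stays open. Also open, going by these compounds, is whether an amine, a carboxylic acid or a longer chain in that place would give a readable value.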